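This account rests on a few compounds, and the source may have more. Where it says the series, first, only, none or still open, it means among the compounds named here.

Working notes on the series, read in an ADME assay on cells (Hepatocyte, Mus musculus) for metabolic stability, with a stated time of 30 min; on this read-out lower numbers stand for a less stable compound and higher numbers for a more stable compound. Compound 1 (`O=C(OC1CCC(CN2CCN(c3cc(=O)c4cc(C(F)(F)F)cc([N+](=O)[O-])c4s3)CC2)CC1)c1ccccc1`) gives 68.1%, compound 2 (`O=C(NC1CCC(CN2CCN(c3cc(=O)c4cc(C(F)(F)F)cc([N+](=O)[O-])c4s3)CC2)CC1)c1ccccc1`) gives 90.6% and compound 3 (`O=C(OC1CCC(CN2CCN(c3cc(=O)c4cc(C(F)(F)F)cc([N+](=O)[O-])c4s3)CC2)CC1)C1CCCCC1`) gives 1.2%, the lowest of the three. The measured steps leading to this low point are a number 66.9 percentage points lower from compound 1 to compound 3 (beyond the scatter) and a number 89.4 percentage points lower from compound 2 to compound 3 (beyond the scatter).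

The next structure is compound 4 (`CC(=O)NC1CCC(CN2CCN(c3cc(=O)c4cc(C(F)(F)F)cc([N+](=O)[O-])c4s3)CC2)CC1`), and the change is acetamido in place of (cyclohexylcarbonyl)oxy on a saturated ring carbon. For the measured compounds named here, two measured steps bear on it. The cyclohexyl of compound 3 leaves, and the step that brought it in was a number 66.9 percentage points lower from compound 1 to compound 3 (beyond the scatter). Going by the values given here, a nitrogen-linked group enters, and the closest precedent is a number 22.5 percentage points higher from compound 1 to compound 2 (beyond the scatter), which ends at compound 2 with benzamido on the same saturated ring carbon. Among the compounds with values here, no measured compound carries acetamido, so the size of the change remains uncertain, particularly at the upper end.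

A large upward step is expected, estimated as a number 82.8 percentage points higher from compound 3 to compound 4 (beyond the scatter). For compound 4 the expected value is 84%, with an estimated range from 60% to 97%.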

Compound 4, percent of the compound remaining: 94.9%
The estimate for compound 4 lay 10.9 percentage points below the measured number, within the range that was stated.
By their numbers in this assay, from the lowest: compound 3; then compound 1; then compounds 2 and 4 (each within the scatter of the next).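

In this assay, the high number at this saturated ring carbon is not confined to benzamido: acetamido gives a number 26.8 percentage points higher from compound 1 to compound 4 (beyond the scatter) and a number 93.7 percentage points higher from compound 3 to compound 4 (beyond the scatter) in the two comparisons with the esters. Methyl in place of phenyl on the carbonyl carbon of the amide gives a number 4.3 percentage points higher from compound 2 to compound 4 (within the scatter) and so does not separate the two amides, whereas cyclohexyl in place of phenyl on the carbonyl carbon of the ester gave a number 66.9 percentage points lower from compound 1 to compound 3 (beyond the scatter).

No measurement offered here accounts for the difference between the amide and ester compounds. Open, going by these compounds, is whether a cyclohexanecarboxamido or acetoxy group would follow the amides or the esters, and whether an amine, a carboxylic acid or a longer chain on this saturated ring carbon would hold the number.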